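Returning an acetylated ring in place of the open hydroxy chain

The compounds below may be only part of what the source reports. "The series", "measured", "known", "first", "only" and "open" are said of these compounds alone.

Measured compounds:
- Compound 1, `CC(C)c1nc2c(C(=O)NCC3CCN(CCN4CCN(S(C)(=O)=O)CC4)CC3)cccc2[nH]1`: 0.794 nM
- Compound 2, `CC(=O)N1CCN(CCN2CCC(CNC(=O)c3cccc4[nH]c(C(C)C)nc34)CC2)CC1`: 3.16 nM
- Compound 3, `CC(=O)N(C)CC(O)CN1CCC(CNC(=O)c2cccc3[nH]c(C(C)C)nc23)CC1`: 1.59 nM

All three compounds were tested in a functional assay for agonist activity at 5-hydroxytryptamine receptor 4 (Homo sapiens), read by cAMP accumulation; on this read-out lower numbers stand for an effect already at smaller amounts and higher numbers for an effect only at larger amounts of compound. Compound 3 stands in the middle of the three numbers, and both of its neighbours lie within the scatter of it: the step of a 2.0-fold higher number from compound 1 to compound 3 (0.30 log units; within the scatter) and the step of a 2.0-fold lower number from compound 2 to compound 3 (0.30 log units; within the scatter) are each too small to count as a change. Among the measured compounds shown here, the only step beyond the scatter among the measured compounds is a 4.0-fold higher number from compound 1 to compound 2 (0.60 log units; beyond the scatter), which exchanges the group on the ring nitrogen and does not touch the part altered here.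

Compound 4, `CC(=O)N1CCC(CN2CCC(CNC(=O)c3cccc4[nH]c(C(C)C)nc34)CC2)CC1`, differs from compound 3 in one place: 1-acetylpiperidin-4-yl in place of 2-(acetyl(methyl)amino)-1-hydroxyethyl on a saturated chain carbon bound to an amine nitrogen in a ring. An acetylated six-membered ring thus comes back onto the saturated carbon, as in compound 2, though now joined through a ring carbon rather than a ring nitrogen and without the hydroxyl. The step of a 2.0-fold lower number from compound 2 to compound 3 (0.30 log units; within the scatter) is the closest guide and was within the scatter, so no step beyond the scatter in either direction is expected for the change to compound 4.

Compound 4 is therefore estimated at 2 nM, with a range from 0.6 nM to 7 nM, which corresponds to an expected step of a 1.3-fold higher number from compound 3 to compound 4 (0.10 log units; within the scatter).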

Compound 4, half-maximal effective concentration: 1.59 nM
Beside the measured number, compound 4's estimate is 1.3-fold (0.10 log units) above it; the measured number falls inside the stated range.
By their numbers in this assay, from the lowest: compounds 1, 3, 4 and 2 (each within the scatter of the next, the first and the last beyond it).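

In this assay, the open 2-(acetyl(methyl)amino)-1-hydroxyethyl group gives way to 1-acetylpiperidin-4-yl on the saturated chain carbon bound to an amine nitrogen in a ring with no change at the digits printed from compound 3 to compound 4 (within the scatter), so for this pair neither the open chain nor the hydrogen-bond donor counted on the leaving group is needed to keep the number where it stands. Set against (4-acetylpiperazin-1-yl)methyl, the same group gives a 2.0-fold lower number from compound 2 to compound 4 (0.30 log units; within the scatter), and set against (4-(methylsulfonyl)piperazin-1-yl)methyl it gives a 2.0-fold higher number from compound 1 to compound 4 (0.30 log units; within the scatter), so at this place neither of the two piperazinyl groups can be told apart from it, even though compound 1 and compound 2 are separated from each other by more than the scatter. No measurement of any other kind is available that bears on why these numbers stay so close together.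

Going by these compounds, whether a carboxylic acid, a primary amine or a longer chain on this saturated chain carbon would carry the number beyond the scatter remains open. Also open, on these data alone, is whether methylsulfonyl in place of the acetyl of 1-acetylpiperidin-4-yl would echo a 4.0-fold higher number from compound 1 to compound 2 (0.60 log units; beyond the scatter).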